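The compounds below may be only part of what the source reports. "The series", "measured", "known", "first", "only" and "open" are said of these compounds alone.

In an ADME assay on SH-SY5Y cells (Homo sapiens) for cytotoxicity, read by MTT assay, with a stated time of 72 h (a higher number here means a weaker inhibitor, a lower number a stronger inhibitor), compound 2 `O=C(CN1CCN(C(=O)c2ccccc2)CC1)N1CCN(CCCc2c[nH]c3ccc(F)cc23)CC1` gives 146000 nM and compound 3 `Cc1ccc(C(=O)N2CCN(CC(=O)N3CCN(CCCc4c[nH]c5ccc(F)cc45)CC3)CC2)cc1` gives 119000 nM. The step between them, a 1.2-fold lower number from compound 2 to compound 3 (0.09 log units; within the scatter), leaves compound 3 level with compound 2. Compound 1 `COc1cccc(C(=O)N2CCN(CC(=O)N3CCN(CCCc4c[nH]c5ccccc45)CC3)CC2)c1`, which carries 3-methoxyphenyl on a carbonyl carbon, reports only a limit, > 200000 nM. Compound 4 `COc1cccc(C(=O)N2CCN(CC(=O)N3CCN(CCCc4c[nH]c5ccc(F)cc45)CC3)CC2)c1` changes compound 3 at that same place: 3-methoxyphenyl in place of 4-methylphenyl on a carbonyl carbon, which puts 3-methoxyphenyl in place of 4-methylphenyl on a carbonyl carbon. Among the compounds with values here, the one measured step that bears on this is the methyl step to compound 3, a 1.2-fold lower number from compound 2 to compound 3 (0.09 log units; within the scatter), and it stays within the scatter. Nothing beyond the scatter is expected here, only a slight lean towards a higher number, with the estimated step being a 1.3-fold higher number from compound 3 to compound 4 (0.10 log units; within the scatter). For compound 4 the estimate is 150000 nM, with an expected range of 90000 nM to 250000 nM.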

Compound 4, half-maximal inhibitory concentration: 79400 nM
Compound 4: the middle estimate sits 1.9-fold (0.28 log units) above what was measured; the measured number lies below the stated range.
By their numbers in this assay, from the lowest: compounds 4, 3 and 2 (each within the scatter of the next). At a limit, above all of these: compound 1.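

In this assay, 3-methoxyphenyl in place of 4-methylphenyl on a carbonyl carbon (a 1.5-fold lower number from compound 3 to compound 4 (0.18 log units; within the scatter)) and the added methoxy (a 1.8-fold lower number from compound 2 to compound 4 (0.26 log units; within the scatter)) both stay within the scatter, so compound 2, compound 3 and compound 4 read alike at this place. Compound 1 reports only a limit (> 200000 nM). Within the data shown here, the added fluoro gives the only new step beyond the scatter (an at least 2.5-fold lower number from compound 1 to compound 4 (0.40 log units; beyond the scatter)), and it lies away from the carbonyl substituent.

On these data alone, whether an amine or a carboxylic acid on this phenyl ring would carry the number beyond the scatter stays open. So does whether chloro in place of fluoro would match that step.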